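A Chlorine for a Nitro Group on the Shared Core

The source may hold more compounds than are shown below. What is called first, only, known or untested is meant among the compounds shown, and "the series" means these compounds.

Compound 2 `COc1cc(/C=C/C(=O)C(=Cc2cn(-c3ccccc3)nc2-c2cccc([N+](=O)[O-])c2)C(=O)/C=C/c2ccc(O)c(OC)c2)ccc1O` stands lowest of the two numbers gathered so far: in a functional assay on MCF7 cells (Homo sapiens) for antiproliferative activity, read by MTT assay, with a stated time of 24 h, tested at 0.001 ug/mL (on this read-out higher numbers stand for a weaker effect at the one concentration tested and lower numbers for a stronger effect), compound 2 gives 96%, while compound 1 `COc1cc(/C=C/C(=O)C(=Cc2cn(-c3ccccc3)nc2-c2ccc([N+](=O)[O-])cc2)C(=O)/C=C/c2ccc(O)c(OC)c2)ccc1O` gives 98%, a pair that sits within the scatter. Compound 3 `COc1cc(/C=C/C(=O)C(=Cc2cn(-c3ccccc3)nc2-c2ccc(Cl)cc2)C(=O)/C=C/c2ccc(O)c(OC)c2)ccc1O` differs from compound 2 by 4-chlorophenyl in place of 3-nitrophenyl on an aromatic carbon. For the measured compounds named here, only one measured step bears on this change: a number 2 percentage points lower from compound 1 to compound 2 (within the scatter), a swap of groups at the same ring carbon that left the read-out unmoved. A further swap at that place is therefore expected to give no step beyond the scatter, no change at the digits printed from compound 2 to compound 3 (within the scatter). Compound 3 is expected to give 96%, with a range from 86% to 100%.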

Compound 3, a percentage reported as activity, at one concentration (the size of the read-out at that concentration, not a potency): 81%
Compound 3: middle estimate off by 15 percentage points, on the high side, outside the stated range (below it).
By their numbers in this assay, from the lowest: compound 3; then compounds 2 and 1 (each within the scatter of the next).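

The earlier pair showed only that 3-nitrophenyl and 4-nitrophenyl give read-outs within the scatter of each other. This position does respond to its group, however: this assay shows a number 15 percentage points lower from compound 2 to compound 3 (beyond the scatter) and a number 17 percentage points lower from compound 1 to compound 3 (beyond the scatter) in the cleaner comparison, where chloro replaces nitro at the same ring carbon. No measurement at hand accounts for this shift. Still open, on these data alone, is whether a phenyl ring carrying an amine or a methoxy group would read like compound 3 or like compound 1 and compound 2.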